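A few compounds are considered here, and "the series" means these few. Any claim that something is new, unique, unknown or untested is made for them only; others in the source may bear on it.

Measured compounds in a functional assay on NCI-H1975 cells (Homo sapiens) for antiproliferative activity, read by MTT assay, with a stated time of 72 h; on this read-out higher numbers stand for weaker inhibition and lower numbers for stronger inhibition:
compound 1 `COc1cc2ncnc(Nc3ccc(F)cc3)c2cc1OCCCCC(=O)Nc1ccc(S(N)(=O)=O)cc1`; compound 1 gives > 40000 nM, which is a limit of the assay rather than a number.
compound 2 `COc1cc2ncnc(Nc3ccccc3)c2cc1OCCCCC(=O)Nc1ccc(S(N)(=O)=O)cc1`; compound 2 gives 14100 nM.
compound 3 `C#Cc1cccc(Nc2ncnc3ccc(NC(=S)Nc4ccc(S(N)(=O)=O)cc4)cc23)c1`; compound 3 gives 13400 nM.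

The values of compound 3 and compound 2 sit within the scatter of each other, and the value of compound 1 is a limit, so compound 3 holds no clear rank among the three. Compound 4 `NS(=O)(=O)c1ccc(NC(=S)Nc2ccc3ncnc(Nc4cccc(Cl)c4)c3c2)cc1` differs from compound 3 by chloro in place of ethynyl on an aromatic carbon. Going by the values given here, the single measured step, an at least 2.8-fold lower number from compound 1 to compound 2 (0.45 log units; beyond the scatter), concerns hydrogen replacing fluoro on an aromatic carbon in a different core and does not match this exchange, so it offers little guidance. The expected step is a 1.0-fold lower number from compound 3 to compound 4 (0.01 log units; within the scatter), within the scatter. Compound 4 is estimated at 13000 nM, between 5000 nM and 35000 nM.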

Compound 4, half-maximal inhibitory concentration: 39800 nM
The estimate for compound 4 lay 3.1-fold (0.49 log units) below the measured number; the whole stated range lies below it.
By their numbers in this assay, from the lowest: compounds 3 and 2 (each within the scatter of the next); then compound 4. At a limit, above all of these: compound 1.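

In this assay the exchange of ethynyl for chloro on this aromatic carbon gives a 3.0-fold higher number from compound 3 to compound 4 (0.47 log units; beyond the scatter), the first step read at this position. This ring therefore responds to the exchange, and ethynyl gives the lower number of the two groups on the thiourea-linked scaffold shared by these two compounds. Compound 1 stands at a limit of the assay, not a number: the limit of > 40000 nM in this assay, at which 1 of the 4 values shown sits.

The compounds shown leave open how hydrogen, an amine or a nitrile would read at this position. As far as these compounds go, whether the same exchange gives a similar step on the core of compound 2 also remains open.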